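Cytotoxicity limits across the oxygen-substituent exchange

A few compounds are considered here, and "the series" means these few. Any claim that something is new, unique, unknown or untested is made for them only; others in the source may bear on it.

Compound 2 `Cc1ncc([N+](=O)[O-])n1CCSC(=S)N1CCC(OS(C)(=O)=O)CC1` carries methylsulfonyl on the oxygen on the saturated carbon. In an ADME assay on HeLa cells (Homo sapiens) for cytotoxicity (a higher number here means a weaker inhibitor, a lower number a stronger inhibitor), compound 2 gives > 1000 ug/mL, which is a limit of the assay and not a number. Compound 1 `Cc1ncc([N+](=O)[O-])n1CCSC(=S)N1CCC(OC(=O)C(Cl)Cl)CC1` carries (dichloromethyl)carbonyl at the same place. In this assay compound 1 gives > 1000 ug/mL, again a limit. Within the data shown here, the step that the two limits leave unreadable from compound 1 to compound 2 is therefore unreadable in size, and the whole series so far sits at the limit of > 1000 ug/mL in this assay, at which 2 of the 2 values shown sit.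

Compound 3 `Cc1ncc([N+](=O)[O-])n1CCSC(=S)N1CCC(OC(=O)CCl)CC1` differs from compound 2 in one place: (chloromethyl)carbonyl in place of methylsulfonyl on an oxygen on a saturated carbon. Among the measured compounds shown here, the only measured step that bears on this exchange is a step that the two limits leave unreadable from compound 1 to compound 2, which swaps an acyl group for the sulfonyl on the same oxygen and gives no readable size. Nothing in the measured values points to a change beyond the scatter in this assay, and the same limit is expected once more. The step from compound 2 to compound 3 is estimated as a step that the limit leaves unreadable from compound 2 to compound 3. For compound 3 the expected reading in this assay is 1500 ug/mL, within 600 ug/mL to 4000 ug/mL.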

Compound 3, half-maximal inhibitory concentration: 930 ug/mL
For compound 3 the middle estimate is 1.6-fold (0.21 log units) above the measured one; measured number inside the range.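

Working notes on the oxygen substituent: In this assay compound 3 gives 930 ug/mL, the only value shown that is a number and not a limit. The exchange of methylsulfonyl for (chloromethyl)carbonyl reads as an at least 1.0-fold lower number from compound 2 to compound 3 (0.03 log units; that floor lies within the scatter), and hydrogen in place of chloro on the saturated chain carbon bound to the carbonyl carbon reads as an at least 1.0-fold lower number from compound 1 to compound 3 (0.03 log units; that floor lies within the scatter). A substituent on this oxygen can therefore give a reading inside the range of the assay, but these floors establish no difference among the three compounds: the limit of > 1000 ug/mL in this assay, at which 2 of the 3 values shown sit.

As far as these compounds go, the true size of both steps stays open, and the step between the two compounds held at the limit cannot be read at all. Also open, from the compounds shown here alone, is what this assay would return for a plain acetyl group, a longer acyl chain or an amine on the same oxygen, and whether any of these would give a number clearly beyond the scatter from compound 3.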